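The compounds below may be only part of what the source reports. "The series", "measured", "known", "first", "only" and "open" are said of these compounds alone.

Compound 1 `CN1CCN(CCCCCn2c3c(c4ccccc42)C(=O)c2c[n+]([O-])c4ccccc4c2C3=O)CC1` shares its core with compound 2 `O=C1c2c[n+]([O-])c3ccccc3c2C(=O)c2c1c1ccccc1n2Cc1cn([C@@H]2C[C@H](O)[C@@H](CO)O2)nn1` and compound 3 `O=C1c2c[n+]([O-])c3ccccc3c2C(=O)c2c1c1ccccc1n2Cc1cn([C@H]2O[C@H](CO)[C@@H](O)[C@H]2O)nn1`. In a toxicity assay on L02 cells (Homo sapiens) for cytotoxicity, read by MTT assay, with a stated time of 72 h (on this read-out lower numbers stand for stronger inhibition and higher numbers for weaker inhibition), compound 1 gives 1640 nM, the highest of the three numbers, though its gap to compound 3 lies within the scatter and only its gap to compound 2 lies beyond it. Compound 2 gives 630 nM and compound 3 gives 950 nM. Among the compounds with values here, the only step between measured compounds that differ in one place is a 1.5-fold higher number from compound 2 to compound 3 (0.18 log units; within the scatter), a change on a saturated ring carbon far from the chain of compound 1. Compound 4 `O=C1c2c[n+]([O-])c3ccccc3c2C(=O)c2c1c1ccccc1n2CCCCN1CCCCC1` differs from compound 1 by piperidin-1-yl in place of (4-methylpiperazin-1-yl)methyl on a saturated chain carbon, four bonds along the chain from an aromatic nitrogen. Within the data shown here, no measured step bears on this change, so no movement beyond the scatter is expected; the expected step is a 1.0-fold lower number from compound 1 to compound 4 (0.01 log units; within the scatter). Compound 4 is therefore estimated at 1600 nM, within a range from 700 nM to 3800 nM.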

Compound 4, half-maximal inhibitory concentration: 610 nM
Compound 4: the middle estimate sits 2.6-fold (0.42 log units) above what was measured, and the stated range ends above it.
By their numbers in this assay, from the lowest: compounds 4, 2, 3 and 1 (each within the scatter of the next, the first and the last beyond it).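

In this assay, piperidin-1-yl in place of (4-methylpiperazin-1-yl)methyl gives a 2.7-fold lower number from compound 1 to compound 4 (0.43 log units; beyond the scatter) and this step lies beyond the scatter. Within the data shown here, the chain end of compound 1 can therefore shift this number, whereas the only earlier step, on a saturated ring carbon, stayed within the scatter. No measurement shown here accounts for the shift.

On these data alone, the ring and the chain length change together in compound 4, and which of them carries the step stays open. Also open, as far as these compounds go, is how a morpholine ring or a longer chain ending in piperidin-1-yl would read here.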